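Adding a bromine to the benzyl group of compound 3

The source may report more compounds than this note shows. Statements on the series, on what has been measured and on what is new or still open speak of the compounds shown alone.

Of the compounds shown here, three sharing one core have been measured in an assay on CHO cells for displacement of a labelled ligand from melanin-concentrating hormone receptor 1 (Rattus norvegicus), read by scintillation counting, with a stated time of 1 h; on this read-out lower numbers stand for stronger inhibition and higher numbers for weaker inhibition. Compound 1 `Cc1nc2ccc(NC(=O)COc3ccc(OC(F)(F)F)cc3)cn2c1C` gives 7.8 nM, and compound 2 `Cc1c(C2CC2)nc2ccc(NC(=O)COc3ccc(OC(F)(F)F)cc3)cn12` gives 6.3 nM. The single difference between them, cyclopropyl in place of methyl on an aromatic carbon, gave a 1.2-fold lower number from compound 1 to compound 2 (0.09 log units; within the scatter). Compound 3 `Cc1c(C2CC2)nc2ccc(-n3ccc(OCc4ccccc4)cc3=O)cn12` carries a different side group and gives 28 nM, the highest of the three numbers; compound 1 lies nearest to it and compound 2 furthest, both gaps beyond the scatter.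

Compound 4 `Cc1c(C2CC2)nc2ccc(-n3ccc(OCc4ccc(Br)cc4)cc3=O)cn12` differs from compound 3 in one place: bromo in place of hydrogen on an aromatic carbon, on a six-membered aromatic ring of carbon only, the ring at the end of the benzyloxy group. Among the compounds with values here, none of the measured steps touches this ring; the only step recorded, from compound 1 to compound 2, alters a different part of the molecule and was within the scatter, so it gives no direct guidance. Within the data shown here, with no comparable step to lean on, a modest change in this assay is expected, possibly toward a lower number, but a result within the scatter of compound 3 cannot be excluded. Compound 4 is therefore estimated at 20 nM, with a range from 7 nM to 60 nM. The expected step is a 1.4-fold lower number from compound 3 to compound 4 (0.15 log units; within the scatter).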

Compound 4, half-maximal inhibitory concentration: 9.3 nM
Compound 4: middle estimate off by 2.2-fold (0.33 log units), on the high side; low and high end bracket the measured number.
By their numbers in this assay, from the lowest: compounds 2, 1 and 4 (each within the scatter of the next); then compound 3.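

In this assay, the ring at the end of the benzyloxy group proves to be a place where a small change can be read: a single bromine atom, entering on an aromatic carbon para to a large group and turning benzyl into 4-bromobenzyl, gives a 3.0-fold lower number from compound 3 to compound 4 (0.48 log units; beyond the scatter). Within the data shown here, this is the first step that lies beyond the scatter, whereas the only earlier step, cyclopropyl in place of methyl on a different part of the molecule, gave a 1.2-fold lower number from compound 1 to compound 2 (0.09 log units; within the scatter) and so showed no clear change. The result therefore shows that this assay can respond to a change at the far end of the side group, although nothing available here accounts for the size or direction of the step.

With only one substituent shown on this ring, it remains open whether chloro, methyl, a nitrile or an amine at the same place would lower the number as bromo does. Also open, as far as these compounds go, is whether a longer chain between the oxygen and the ring would keep the gain seen with the 4-bromobenzyl group.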